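This account rests on a few compounds, and the source may have more. Where it says the series, first, only, none or still open, it means among the compounds named here.

Measured compounds:
- compound 1, `O=C(NCCCNc1nc(Nc2cccc(F)c2)ncc1Br)c1cccs1`: 9 nM
- compound 2, `O=C(CCc1ccccc1)NCCCNc1nc(Nc2cccc(F)c2)ncc1Br`: 560 nM
- compound 3, `O=C(NCCCNc1nc(Nc2cccc(F)c2)ncc1Br)c1ccc(C(F)(F)F)cc1`: 450 nM

All three were tested in an assay on isolated protein for inhibition of serine/threonine-protein kinase TBK1 (Homo sapiens); a lower number here means a stronger inhibitor, a higher number a weaker inhibitor. Among the three, compound 3 gives the second highest number; its nearest neighbour is compound 2, and the gap between them, a 1.2-fold lower number from compound 2 to compound 3 (0.09 log units; within the scatter), lies within the scatter. Compound 1 stands far from both, as shown by a 62-fold higher number from compound 1 to compound 2 (1.79 log units; beyond the scatter) and a 50-fold higher number from compound 1 to compound 3 (1.70 log units; beyond the scatter).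

Compound 4, `COCCC(=O)NCCCNc1nc(Nc2cccc(F)c2)ncc1Br`, is not yet measured. It differs from compound 3 at the carbonyl carbon: 2-methoxyethyl in place of 4-(trifluoromethyl)phenyl on a carbonyl carbon

The step that bears most directly on this change is a 1.2-fold lower number from compound 2 to compound 3 (0.09 log units; within the scatter), where swapping one non-thiophene acyl group for another left the number essentially unchanged. The two large steps, a 62-fold higher number from compound 1 to compound 2 (1.79 log units; beyond the scatter) and a 50-fold higher number from compound 1 to compound 3 (1.70 log units; beyond the scatter), show that only the thiophen-2-yl group reaches the low range. Because compound 3 sits at 450 nM and the exchange of acyl groups between compound 2 and compound 3 moved little, the number for compound 4 is expected to stay near the high range, with a 1.4-fold higher number from compound 3 to compound 4 (0.16 log units; within the scatter) expected to fall within or only slightly beyond the scatter. Compound 4 is therefore estimated at 650 nM, within the range 220 nM to 2000 nM.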

Compound 4, half-maximal inhibitory concentration: 60 nM
Beside the measured number, compound 4's estimate is 11-fold (1.03 log units) above it; measured number outside the range, below it.
By their numbers in this assay, from the lowest: compound 1; then compound 4; then compounds 3 and 2 (each within the scatter of the next).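

In this assay, the acyl group on the carbonyl carbon separates compounds that lack the thiophen-2-yl group, which compound 2 and compound 3 alone had not shown: there is a 7.5-fold lower number from compound 3 to compound 4 (0.88 log units; beyond the scatter) and also a 9.3-fold lower number from compound 2 to compound 4 (0.97 log units; beyond the scatter) for the change on the chain. A 2-methoxyethyl group, with no ring, therefore gives a lower number than either group carrying a six-membered aromatic ring, yet it does not match thiophen-2-yl, as a 6.7-fold higher number from compound 1 to compound 4 (0.82 log units; beyond the scatter) shows. No measurement shown explains these differences. The compounds shown leave open whether the lower number goes with the oxygen of the 2-methoxyethyl group or with the loss of the ring, a question that an all-carbon butyl group on the same carbonyl carbon would address. On these data alone, how an amine or a carboxylic acid at the end of that chain, or a longer chain, would behave also remains open.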